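A few compounds are considered here, and "the series" means these few. Any claim that something is new, unique, unknown or untested is made for them only; others in the source may bear on it.

The three measured compounds in an assay on MDA-MB-231 cells for displacement of a labelled ligand from C-X-C chemokine receptor type 4 (Homo sapiens), read by fluorescence and microscopy, with stated times of 10 min and 30 min; on this read-out lower numbers stand for an effect already at smaller amounts and higher numbers for an effect only at larger amounts of compound:
Compound 1 `Cc1ccccc1C(=O)NCc1ccc(CNS(=O)(=O)c2ccc([N+](=O)[O-])cc2)cc1` gives 100 nM.
Compound 2 `Cc1ccccc1C(=O)NCc1ccc(CNS(=O)(=O)c2ccccc2F)cc1` gives 1000 nM.
Compound 3 `O=C(NCc1ccc(CNS(=O)(=O)c2cccc3ccccc23)cc1)c1cccnc1` gives 1000 nM.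

Compound 3 stands level with compound 2 at the digits shown, the two of them sharing the highest number of the three, while compound 1 shows a clearly smaller number in this assay. Among the compounds with values here, the only measured step, a 10-fold higher number from compound 1 to compound 2 (1.00 log units; beyond the scatter), concerns the group on the sulfonyl sulfur and does not touch the change that leads to compound 4 `Cc1ccccc1C(=O)NCc1ccc(CNS(=O)(=O)c2cccc3ccccc23)cc1`, which is 2-methylphenyl in place of pyridin-3-yl on a carbonyl carbon. Compound 4 thus carries the group on the carbonyl carbon found in compounds 1 and 2 together with the group on the sulfonyl sulfur found in compound 3. Within the data shown here, no measured pair isolates the group on the carbonyl carbon, so nothing beyond the scatter is expected from this swap in this assay. The step of a 1.1-fold lower number from compound 3 to compound 4 (0.05 log units; within the scatter) is expected to stay within the scatter. Compound 4 is therefore estimated at 900 nM, with a range from 300 nM to 3000 nM.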

Compound 4, effective concentration (reported as EC, without a stated level of effect): 100 nM
Compound 4: middle estimate off by 9.0-fold (0.95 log units), on the high side; measured number outside the range, below it.
By their numbers in this assay, from the lowest: compounds 1 and 4 (each within the scatter of the next); then compounds 2 and 3 (each within the scatter of the next).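

In this assay the group on a carbonyl carbon now has a measured pair of its own: with naphthalen-1-yl on the sulfonyl sulfur, 2-methylphenyl in place of pyridin-3-yl gives a 10-fold lower number from compound 3 to compound 4 (1.00 log units; beyond the scatter), so this position matters at least in this setting. The sulfonyl sulfur also gains two readings with 2-methylphenyl on the carbonyl carbon: naphthalen-1-yl in place of 2-fluorophenyl gives a 10-fold lower number from compound 2 to compound 4 (1.00 log units; beyond the scatter), while naphthalen-1-yl in place of 4-nitrophenyl gives no change at the digits printed from compound 1 to compound 4 (within the scatter), which places these two groups on the sulfonyl sulfur level with each other. No measurement offered here accounts for either result.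

The compounds shown leave open whether the step on the carbonyl carbon carries over when 4-nitrophenyl or 2-fluorophenyl sits on the sulfonyl sulfur. They also leave open how a carboxylic acid or an amine-bearing chain in place of 2-methylphenyl would read.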